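Three near-silent compounds and one untested aryl swap

The source may report more compounds than this note shows. Statements on the series, on what has been measured and on what is new or still open speak of the compounds shown alone.

- Compound 1 `Cc1oc2c([C@H]3CCN(C)C[C@H]3O)c(O)cc(O)c2c(=O)c1C(O)c1cccc(Cl)c1`: 2%
- Compound 2 `Cc1oc2c([C@H]3CCN(C)C[C@H]3O)c(O)cc(O)c2c(=O)c1C(O)c1ccccc1Br`: 10%
- Compound 3 `Cc1oc2c([C@H]3CCN(C)C[C@H]3O)c(O)cc(O)c2c(=O)c1C(O)c1c(Cl)cccc1Cl`: 0%

In a functional assay on MIA PaCa-2 cells (Homo sapiens) for inhibition, read by MTT assay, with a stated time of 48 h, tested at 10 uM (on this read-out higher numbers stand for more inhibition of growth at the one concentration tested and lower numbers for less inhibition of growth), compound 3 gives 0%, level within the scatter with both other compounds. Compound 4 `COc1ccc(C(O)c2c(C)oc3c([C@H]4CCN(C)C[C@H]4O)c(O)cc(O)c3c2=O)cc1Br` differs from it at one place: 3-bromo-4-methoxyphenyl in place of 2,6-dichlorophenyl on a saturated chain carbon bound to an aromatic carbon and an oxygen on a saturated carbon. Three swaps of the group at this same place have been measured: a number 8 percentage points higher from compound 1 to compound 2 (within the scatter), a number 2 percentage points lower from compound 1 to compound 3 (within the scatter) and a number 10 percentage points lower from compound 2 to compound 3 (within the scatter). Going by the values given here, none goes beyond the scatter, but none of the measured compounds carries a methoxy group, so this evidence is indirect. No step beyond the scatter is therefore expected in this assay. The expected change is a number 4 percentage points higher from compound 3 to compound 4 (within the scatter). Compound 4 is estimated at 4%, with an expected range of 0% to 15%.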

Compound 4, percent growth inhibition at one concentration: 3%
Estimate against measurement, compound 4: 1 percentage points above; the range from low to high includes it.
By their numbers in this assay, from the lowest: compounds 3, 1, 4 and 2 (each within the scatter of the next).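

In this assay, bringing a methoxy group into this position on the saturated chain carbon does not move the read-out beyond the scatter: the result is a number 3 percentage points higher from compound 3 to compound 4 (within the scatter) and a number 7 percentage points lower from compound 2 to compound 4 (within the scatter) and a number 1 percentage points higher from compound 1 to compound 4 (within the scatter). Among these four compounds, then, neither the halogen pattern nor the added methoxy group separates one aryl group from another. Nothing available here explains this flat result.

As far as these compounds go, whether an aryl ring carrying an amine or a carboxylic acid would behave the same remains open. So does the effect of a longer alkyl chain in place of the aryl ring.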